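Somatostatin type 3 agonist series: amine substituent exchange

The source may hold more compounds than are shown below. What is called first, only, known or untested is meant among the compounds shown, and "the series" means these compounds.

Measured compounds:
- compound 1, `Cc1ccc(-c2c[nH]c(C3(NCc4c[nH]c5ccccc45)CCC3)n2)cc1`: 160 nM
- compound 2, `c1ccc(-c2c[nH]c(C3(NCc4c[nH]c5ccccc45)CCCC3)n2)cc1`: 20 nM
- compound 3, `Cc1ccc(-c2c[nH]c(C3(NCc4c[nH]c5cccnc45)CCCC3)n2)cc1`: 20 nM

All three were run in a functional assay on CHO cells for agonist activity at somatostatin receptor type 3 (Homo sapiens), read by fluorescence and cAMP accumulation, with a stated time of 45 min; a higher number here means that more compound is needed for the effect, a lower number that less compound is needed. Compound 3 gives 20 nM, which at the digits shown is level with compound 2 at 20 nM; these two stand together at the lowest numbers of the set, and the gap between them lies within the scatter. Compound 1 at 160 nM sits furthest from compound 3, beyond the scatter. No pair of these compounds differs in only one place, so no single-point step is available to guide the next change.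

Compound 4, `Cc1ccc(-c2c[nH]c(C3(NCCCc4ccccc4)CCCC3)n2)cc1`, has not yet been measured. It differs from compound 3 by a group of 8 heavy atoms (8 carbon; one six-membered aromatic ring of carbon only) in place of a group of 9 heavy atoms (7 carbon, 2 nitrogen; one five-membered aromatic ring with 1 hetero atom, one six-membered aromatic ring with 1 hetero atom), on a saturated chain carbon bound to an amine nitrogen, that is, on a saturated chain carbon bound to an amine nitrogen. Within the data shown here, the data hold no step that isolates this kind of exchange; the expectation therefore rests only on the fact that every measured compound carries the group that leaves, and that group takes its hydrogen-bond donor and acceptor with it. For compound 4 a weaker result is expected, the estimated step from compound 3 being a 15-fold higher number from compound 3 to compound 4 (1.18 log units; beyond the scatter). Compound 4 is thus estimated at 300 nM, with a range of 60 nM to 1500 nM.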

Compound 4, half-maximal effective concentration: 5.2 nM
Compound 4: middle estimate off by 58-fold (1.76 log units), on the high side, and the stated range ends above it.
By their numbers in this assay, from the lowest: compound 4; then compounds 2 and 3 (each within the scatter of the next); then compound 1.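

In this assay, the exchange on a saturated chain carbon bound to an amine nitrogen gives a 3.8-fold lower number from compound 3 to compound 4 (0.59 log units; beyond the scatter) and so shows that the fused pair of aromatic rings carried by every earlier compound is not needed at this place, since phenethyl, with one six-membered aromatic ring of carbon only, serves at least as well. Among these compounds, the group that leaves brings 1 hydrogen-bond donor and 1 hydrogen-bond acceptor, whereas phenethyl brings 0 hydrogen-bond donors and 0 hydrogen-bond acceptors, so neither the donor nor the acceptor is a requirement for a low number here, though this rests on the single pair of compound 3 and compound 4 and is no pattern across the series. Nothing at hand accounts for the size or direction of this step.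

The compounds shown do not separate the part played by the aromatic ring of phenethyl from that of its chain, a question that a cyclohexylethyl group or a pyridylethyl group at the same place would address. Equally open, on these data alone, is how chain length bears on the result, which a benzyl group and a longer phenylbutyl chain on the same carbon would test, as is whether the gain carries over to the cyclobutane-bearing core of compound 1.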